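The source may hold more compounds than are shown below. What is called first, only, known or untested is meant among the compounds shown, and "the series" means these compounds.

Within the data shown here, in an assay on CHO cells for agonist activity at Neuronal acetylcholine receptor; alpha3/alpha6/beta2/beta3 (Homo sapiens), read by FLIPR and calcium flux (a lower number here means a smaller maximal response, a higher number a larger maximal response), compound 1 `CCC(=O)N1CC2CC(C1)N2` gives 120%, the highest of the two numbers known so far; compound 2 `CCCC(=O)N1CC2CC(C1)N2` gives 92%. Among the measured compounds shown here, the single measured step, a number 28 percentage points lower from compound 1 to compound 2 (beyond the scatter), came with methyl in place of hydrogen on a saturated chain carbon, two bonds along the chain from a carbonyl carbon. Compound 3 `O=C([C@@H]1C[C@@H]1F)N1CC2CC(C1)N2` carries 2-fluorocyclopropyl in place of ethyl on a carbonyl carbon, also a change at the carbonyl carbon. For the measured compounds named here, with that one step as the only guide, a modest downward step, a number 25 percentage points lower from compound 1 to compound 3 (beyond the scatter), is expected for compound 3 in this assay. Compound 3 is estimated at 95%, with a range from 70% to 120%.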

Compound 3, largest response reached (Emax), in percent of the reference or control that the assay uses: 120%
For compound 3 the middle estimate is 25 percentage points below the measured one; the range from low to high includes it.
By their numbers in this assay, from the lowest: compound 2; then compounds 1 and 3 (each within the scatter of the next).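

In this assay, the carbonyl carbon accepts more than a plain chain: 2-fluorocyclopropyl in place of ethyl brings no change at the digits printed from compound 1 to compound 3 (within the scatter), so adding heavy atoms at this position need not lower the maximal response. Measured against propyl, the same group brings a number 28 percentage points higher from compound 2 to compound 3 (beyond the scatter), which shows that the drop seen with propyl does not apply to every larger group here. No measurement available bears on why these groups differ. The compounds shown leave open whether the ring or the fluorine matters, which unsubstituted cyclopropyl would address. On these data alone, the response to butyl, a longer chain, also remains open.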